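This account rests on a few compounds, and the source may have more. Where it says the series, first, only, none or still open, it means among the compounds named here.

Series notes: three compounds of the shared core have been measured in a functional assay on HL-60 cells (Homo sapiens) for antiproliferative activity, read by MTT assay, with a stated time of 72 h; on this read-out lower numbers stand for stronger inhibition and higher numbers for weaker inhibition. Compound 1 `NC1=NC2(CCOCC2)N(OCCCOc2ccc(F)cc2)C(N)=N1` gives 2380 nM. Compound 2 `Cc1ccc(OCCCON2C(N)=NC(N)=NC23CCOCC3)cc1` gives 2580 nM. Compound 3 `NC1=NC2(CCOCC2)N(OCCCOc2ccc(Cl)cc2Cl)C(N)=N1` gives 330 nM, the lowest of the three numbers. The step of a 1.1-fold higher number from compound 1 to compound 2 (0.04 log units; within the scatter) stays within the scatter, while the steps of a 7.2-fold lower number from compound 1 to compound 3 (0.86 log units; beyond the scatter) and a 7.8-fold lower number from compound 2 to compound 3 (0.89 log units; beyond the scatter) are modest but clear.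

Compound 4 `NC1=NC2(CCOCC2)N(OCCCOc2ccccc2)C(N)=N1` is not yet measured. Against compound 3 the change is phenyl in place of 2,4-dichlorophenyl on an oxygen on a saturated carbon. Within the data shown here, the steps that bear on this are the two that lead into compound 3: a 7.2-fold lower number from compound 1 to compound 3 (0.86 log units; beyond the scatter) and a 7.8-fold lower number from compound 2 to compound 3 (0.89 log units; beyond the scatter) both show the 2,4-dichlorophenyl arriving on the oxygen on a saturated carbon with a lower number, and each aryl group it replaced carried a single substituent. Phenyl carries none, and no measured pair shows an unsubstituted phenyl at this place, so whether it behaves like 4-fluorophenyl and 4-methylphenyl or differs from them is open. The expectation is that compound 4, with the dichlorophenyl gone, loses most of that gain, an estimated step of a 9.1-fold higher number from compound 3 to compound 4 (0.96 log units; beyond the scatter) back towards the numbers of compound 1 and compound 2, with room for a somewhat higher value. Compound 4 is therefore expected to give 3000 nM in this assay, in the range 1200 nM to 8000 nM.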

Compound 4, half-maximal inhibitory concentration: 2460 nM
Estimate against measurement, compound 4: 1.2-fold (0.09 log units) above, within the range that was stated.
By their numbers in this assay, from the lowest: compound 3; then compounds 1, 4 and 2 (each within the scatter of the next).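

In this assay, compound 4 adds the unsubstituted reference at this place: a 1.0-fold lower number from compound 2 to compound 4 (0.02 log units; within the scatter) and a 1.0-fold higher number from compound 1 to compound 4 (0.01 log units; within the scatter) both stay within the scatter, so the loss of neither the methyl nor the fluoro shows a measurable difference. Against this reference, a 7.5-fold higher number from compound 3 to compound 4 (0.87 log units; beyond the scatter) puts the separation on the 2,4-dichlorophenyl group alone, since among these four compounds phenyl, 4-fluorophenyl and 4-methylphenyl form one group and only compound 3 stands apart from it. No measurement at hand accounts for this separation.

The compounds shown leave open whether a single chlorine on the phenyl ring accounts for the step or whether both chlorines of the 2,4-dichlorophenyl group are required, and whether other groups on that ring, such as bromo, trifluoromethyl or methoxy, would behave like the chlorines. Going by these compounds, it is also open whether the 2,4-dichlorophenyl group would keep its lower number with a longer chain in place of the present one on the oxygen.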